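The source may hold more compounds than are shown below. What is called first, only, known or untested is meant among the compounds shown, and "the series" means these compounds.

Working notes on the silicon-bearing series.

Compound 1 `CCN(C/C=C/C#CC(C)(C)C)Cc1cccc(OC[Si](C)(C)c2ccc(C)cc2)c1` gives 120 nM in a functional assay on liver (Sus scrofa) for inhibition of squalene monooxygenase (Homo sapiens), using microsomes; on this read-out lower numbers stand for stronger inhibition and higher numbers for weaker inhibition. Among the measured compounds shown here, compound 2 `CCN(C/C=C/C#CC(C)(C)C)Cc1cccc(OC[Si](C)(C)Cc2ccccc2)c1` gives 130 nM in this assay, the higher of the two numbers so far, with compound 1 as its only neighbour; the step of a 1.1-fold higher number from compound 1 to compound 2 (0.03 log units; within the scatter) shows that exchanging the group on the silicon between an aromatic ring and a benzyl leaves the number where it was.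

Compound 3 `CCN(C/C=C/C#CC(C)(C)C)Cc1cccc(OC[Si](C)(C)C2CCCCC2)c1` is the next member and has not yet been measured. It differs from compound 2 in one place: cyclohexyl in place of benzyl on a silicon. For the measured compounds named here, the only measured step that touches the same silicon is the one from compound 1 to compound 2, which stayed within the scatter, so the substituent on the silicon has so far made no visible difference in this assay. Going by the values given here, no measured step covers the loss of the aromatic ring itself, so the expectation rests on that single step alone.

The working expectation for compound 3 is therefore a step of about a 1.2-fold higher number from compound 2 to compound 3 (0.06 log units; within the scatter) in this assay, that is, nothing beyond the scatter, and the estimate for compound 3 is 150 nM, with a range of 60 nM to 400 nM.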

Compound 3, half-maximal inhibitory concentration: 20000 nM
Compound 3: middle estimate off by 130-fold (2.12 log units), on the low side; the whole stated range lies below it.
By their numbers in this assay, from the lowest: compounds 1 and 2 (each within the scatter of the next); then compound 3.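

At the silicon, the group is not indifferent after all: cyclohexyl in place of benzyl brings a 150-fold higher number from compound 2 to compound 3 (2.19 log units; beyond the scatter) in this assay and cyclohexyl in place of 4-methylphenyl brings a 170-fold higher number from compound 1 to compound 3 (2.22 log units; beyond the scatter) on the same silicon. The agreement between compound 1 and compound 2 therefore holds only for two groups that each carry a six-membered aromatic ring of carbon, and among these three compounds the number stays low only with such a ring, while compound 3 with its six-membered non-aromatic ring stands far apart from both. No data at hand bear on the reason for a step of this size.

The compounds shown leave open whether the aromatic ring as such is what counts or whether the cyclohexyl group alone is poorly accepted, and a cyclohexylmethyl group, a pyridyl ring or an open hexyl chain on the silicon would separate these two readings. They also leave open how much larger the aromatic group can become, as a naphthyl group on the silicon would show.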